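Aryl sulfonamide piperidinyl-piperidines: ortho substituent swap

This account rests on a few compounds, and the source may have more. Where it says the series, first, only, none or still open, it means among the compounds named here.

The series shares a bis-piperidine sulfonamide core and varies the aromatic ring attached to the sulfonyl group. Compound 1 `Cc1cc(Cl)cc(Cl)c1S(=O)(=O)N1CCC(N2CCC(C)CC2)CC1` gives 0.45 nM in a functional assay on HT-29 cells (Homo sapiens) for antiproliferative activity, read by CellTiter-Glo, with a stated time of 72 h; on this read-out higher numbers stand for weaker inhibition and lower numbers for stronger inhibition. Compound 2 `CCc1cc(Br)ccc1S(=O)(=O)N1CCC(N2CCC(C)CC2)CC1` gives 0.5 nM in this assay, and on the numbers shown it sits alongside compound 1: the two values differ by less than the usual scatter, so neither can be set apart from the other.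

Compound 3 `CC1CCN(C2CCN(S(=O)(=O)c3ccc(Br)cc3OC(F)(F)F)CC2)CC1` is the next analogue, not yet measured. Relative to compound 2 the change is trifluoromethoxy in place of ethyl on an aromatic carbon, with the bromo group retained. For the measured compounds named here, no measured pair in this set isolates such a change, so the expectation rests on the closeness of compound 1 and compound 2 alone. Compound 3 is expected to remain in the same potency range, with at most a modest weakening, a 2.0-fold higher number from compound 2 to compound 3 (0.30 log units; within the scatter) being the estimated step. The estimate for compound 3 in this assay is 1 nM, with a range from 0.3 nM to 4 nM.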

Compound 3, half-maximal inhibitory concentration: 4 nM
Beside the measured number, compound 3's estimate is 4.0-fold (0.60 log units) below it, and the stated range covers the measured number.
By their numbers in this assay, from the lowest: compounds 1 and 2 (each within the scatter of the next); then compound 3.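

In this assay, for the compounds shown here, trifluoromethoxy in place of ethyl on an aromatic carbon, ortho to a large group and meta to a bromo group, gives an 8.0-fold higher number from compound 2 to compound 3 (0.90 log units; beyond the scatter) and is the first step in this set to lie beyond the scatter. With the bromo group retained and the rest of the structure unchanged across the pair, this position is shown to respond to the group it carries, which the earlier compounds, differing in more than one place, could not show. Nothing available here bears on the reason for this step.

Open, from the compounds shown here alone, is whether methoxy, an amine or a longer chain such as propyl at this position would track with ethyl or with trifluoromethoxy. Also open, going by these compounds, is whether the same swap would give a similar step on the ring of compound 1, which carries two chloro groups.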